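Compound 3 and its trifluoromethyl analogue

The source may hold more compounds than are shown below. What is called first, only, known or untested is meant among the compounds shown, and "the series" means these compounds.

In a functional assay on U-937 cells (Homo sapiens) for antiproliferative activity, read by MTT assay, with a stated time of 72 h (a higher number here means a weaker inhibitor, a lower number a stronger inhibitor), compound 3 (`Cc1ccc(-c2noc(CCCCCCC(=O)C(F)(F)F)n2)cc1`) gives 3730 nM. That lies within the scatter of both compound 1 (`O=C(CCCCCCc1nc(-c2ccc(C(F)(F)F)cc2)no1)NO`) at 2870 nM and compound 2 (`Nc1ccccc1NC(=O)CCCCCCc1nc(-c2ccc(C(F)(F)F)cc2)no1`) at 5280 nM. Compound 4 (`O=C(CCCCCCc1nc(-c2ccc(C(F)(F)F)cc2)no1)C(F)(F)F`) carries trifluoromethyl in place of methyl on an aromatic carbon of compound 3 (trifluoromethyl in place of methyl on an aromatic carbon). For the measured compounds named here, no measured step isolates this exchange. The only one available, a 1.8-fold higher number from compound 1 to compound 2 (0.26 log units; within the scatter), lies within the scatter and concerns 2-aminophenyl in place of hydroxy on an amide-type nitrogen, so it bears on this change only indirectly. No shift beyond the scatter is therefore expected, and the estimated step is a 1.1-fold lower number from compound 3 to compound 4 (0.03 log units; within the scatter). For compound 4 the expected value is 3500 nM, with an estimated range of 1700 nM to 7000 nM.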

Compound 4, half-maximal inhibitory concentration: 1960 nM
The estimate for compound 4 lay 1.8-fold (0.25 log units) above the measured number; low and high end bracket the measured number.
By their numbers in this assay, from the lowest: compounds 4, 1, 3 and 2 (each within the scatter of the next, the first and the last beyond it).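

In this assay, for the compounds shown here, trifluoromethyl in place of methyl on an aromatic carbon gives a 1.9-fold lower number from compound 3 to compound 4 (0.28 log units; within the scatter) and so offers the first direct reading of this exchange, para to a large group, with no shift beyond the scatter. With trifluoromethyl on the carbonyl carbon, the exchange for (2-aminophenyl)amino gives a 2.7-fold lower number from compound 2 to compound 4 (0.43 log units; beyond the scatter) while the exchange for hydroxyamino gives a 1.5-fold lower number from compound 1 to compound 4 (0.17 log units; within the scatter) and only the former exceeds the scatter. No measurement offered here explains these steps.

From the compounds shown here alone, whether a chloro or methoxy group on that aromatic carbon would read alike stays open. So does the effect of a longer chain on the shared core.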